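The compounds below may be only part of what the source reports. "The series", "measured", "known", "first", "only" and "open" are said of these compounds alone.

In an ADME assay on MT4 cells (Homo sapiens) for cytotoxicity, read by MTT assay (a higher number here means that more compound is tolerated, a lower number that less compound is tolerated), compound 1 `Cc1cc(C)cc(S(=O)(=O)c2c(C(=O)Nc3ccc(O)cc3)[nH]c3ccc(Cl)cc23)c1` gives 18100 nM. Compound 3 `Cc1cc(C)cc(S(=O)(=O)c2c(C(=O)NC(C)c3ccccc3O)[nH]c3ccc(Cl)cc23)c1` gives 21800 nM, which puts it level with compound 1: the step is a 1.2-fold higher number from compound 1 to compound 3 (0.08 log units; within the scatter). Compound 2 `Cc1cc(C)cc(S(=O)(=O)c2c(C(=O)NCc3ccccc3N)[nH]c3ccc(Cl)cc23)c1` gives 46200 nM, and it stands apart from compound 1, with a 2.6-fold higher number from compound 1 to compound 2 (0.41 log units; beyond the scatter). It also stands apart from compound 3, with a 2.1-fold lower number from compound 2 to compound 3 (0.33 log units; beyond the scatter).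

Compound 4 `Cc1cc(C)cc(S(=O)(=O)c2c(C(=O)NCc3cccc(O)c3)[nH]c3ccc(Cl)cc23)c1` has not been measured. It differs from compound 1 as follows: 3-hydroxybenzyl in place of 4-hydroxyphenyl on an amide-type nitrogen. This places 3-hydroxybenzyl in place of 4-hydroxyphenyl on an amide-type nitrogen.

Within the data shown here, two measured steps bear on this change, since both replace the same 4-hydroxyphenyl on that nitrogen. The step to compound 2, a 2.6-fold higher number from compound 1 to compound 2 (0.41 log units; beyond the scatter), brings in 2-aminobenzyl. The step to compound 3, a 1.2-fold higher number from compound 1 to compound 3 (0.08 log units; within the scatter), brings in a larger group that also holds oxygen, and it is the closer guide. Among the measured compounds shown here, no measured compound carries 3-hydroxybenzyl itself, so the size of the step remains uncertain. A small rise in this assay is expected, most likely staying inside the scatter.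

The estimated step is a 1.5-fold higher number from compound 1 to compound 4 (0.19 log units; within the scatter). For compound 4 the expected value is 28000 nM, with an estimated range of 13000 nM to 60000 nM.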

Compound 4, half-maximal cytotoxic concentration: 27000 nM
Compound 4: the middle estimate sits 1.0-fold (0.02 log units) above what was measured; the range from low to high includes it.
By their numbers in this assay, from the lowest: compounds 1, 3, 4 and 2 (each within the scatter of the next, the first and the last beyond it).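

In this assay, the change on the amide-type nitrogen from 4-hydroxyphenyl to 3-hydroxybenzyl gives a 1.5-fold higher number from compound 1 to compound 4 (0.17 log units; within the scatter) and so does not separate the two compounds, while the other hydroxyl-bearing group shows a 1.2-fold higher number from compound 3 to compound 4 (0.09 log units; within the scatter) and leaves these three compounds without a resolved difference. The new compound also shows a 1.7-fold lower number from compound 2 to compound 4 (0.23 log units; within the scatter), so 3-hydroxyphenyl in place of 2-aminophenyl on the saturated chain carbon is not resolved either, and compound 4 lies within the scatter of both ends of the earlier gap, a 2.6-fold higher number from compound 1 to compound 2 (0.41 log units; beyond the scatter). Among these compounds, this leaves that gap as the only step here beyond the scatter that touches compound 1, and no measurement at hand accounts for any of these steps.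

Still open, from the compounds shown here alone, is whether a carboxylic acid, a basic amine such as a dimethylaminoalkyl group or a longer chain between the amide-type nitrogen and the ring would move the number clearly outside this narrow band. Also open is how 4-hydroxybenzyl or 3-aminobenzyl would stand against compound 4 and compound 2, since neither group appears among the compounds shown.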